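Swapping a hydroxymethyl for an oxolane ring

A few compounds are considered here, and "the series" means these few. Any claim that something is new, unique, unknown or untested is made for them only; others in the source may bear on it.

Measured compounds:
- Compound 1, `COc1ccc(Cn2c(-c3ccccc3)c(-c3ccccc3)c3c(=N)n(CCO)cnc32)cc1`, gives 0.518 h in an ADME assay on microsomes from liver (Mus musculus, strain CD1) for metabolic stability, read by LC-MS, using NADPH, with a stated time of 60 min; a higher number here means that the compound lasts longer, a lower number that the compound disappears faster.
- Compound 2, `N=c1c2c(-c3ccccc3)c(-c3ccccc3)n(Cc3ccccc3)c2ncn1C1CCN(Cc2ccccc2)CC1`, gives 0.537 h in this assay.

Compound 1 holds the lowest of the two numbers in this assay, but compound 2 sits so close that the two values lie within the scatter of the method, so neither can be called more or less stable than the other. Within the data shown here, the two compounds differ in several places at once, so no single step between them is set out here; only their two values speak.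

The unmeasured compound 3, `COc1ccc(Cn2c(-c3ccccc3)c(-c3ccccc3)c3c(=N)n(CC4CCCO4)cnc32)cc1`, is built from compound 1 by one change: oxolan-2-yl in place of hydroxymethyl on a saturated chain carbon bound to an aromatic nitrogen. Among the measured compounds shown here, no measured pair in this set shows the effect of such a change, so there is no step to lean on. Without that guide, the expectation is a small step from compound 1 to compound 3 in this assay, a 1.2-fold lower number from compound 1 to compound 3 (0.06 log units; within the scatter), roughly within the scatter and not clearly in either direction. Compound 3 is therefore estimated at 0.45 h, with a range from 0.2 h to 1 h.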

Compound 3, half-life: 0.157 h
Beside the measured number, compound 3's estimate is 2.9-fold (0.46 log units) above it, outside the stated range (below it).
By their numbers in this assay, from the lowest: compound 3; then compounds 1 and 2 (each within the scatter of the next).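

At the saturated chain carbon bound to an aromatic nitrogen, placing oxolan-2-yl where hydroxymethyl stood gives, in this assay, a 3.3-fold lower number from compound 1 to compound 3 (0.52 log units; beyond the scatter), a step beyond the scatter of the method. Compounds 1 and 2 differ in several places and lie within the scatter of each other, so they could not show what one change does here; with the rest of compound 1 kept intact, this pair shows that the group at this position can alter how long the compound lasts in this test. No measurement at hand gives a reason for this step.

This single change removes a hydrogen-bond donor and adds a five-membered non-aromatic ring at the same time, so the compounds shown leave open which of the two goes with the shorter half-life; a 2-methoxyethyl chain, which has no hydroxyl and no ring, would help to tell them apart. As far as these compounds go, it also remains open how this position would respond to quite different groups, such as an amine, a carboxylic acid or a longer chain ending in a hydroxyl.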